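A few compounds are considered here, and "the series" means these few. Any claim that something is new, unique, unknown or untested is made for them only; others in the source may bear on it.

In a functional assay on SW1573 cells (Homo sapiens) for antiproliferative activity, read by sulforhodamine B assay, with a stated time of 48 h (on this read-out higher numbers stand for weaker inhibition of growth and lower numbers for stronger inhibition of growth), three compounds that share one core have been measured. Compound 1 `CCCCC(C#CC(=O)OC)O/C=C/C(=O)OC` gives 240 nM and compound 2 `CCCC(C#CC(=O)OC)O/C=C/C(=O)OC` gives 320 nM. The step of a 1.3-fold higher number from compound 1 to compound 2 (0.12 log units; within the scatter) lies within the scatter, so the butyl and propyl chains cannot be told apart here. Compound 3 `COC(=O)C#CC(O/C=C/C(=O)OC)C(C)(C)C` gives 3000 nM, the highest number of the three and the weakest inhibition of growth in the set. The two steps leading to it are a 13-fold higher number from compound 1 to compound 3 (1.10 log units; beyond the scatter), which is large, and a 9.4-fold higher number from compound 2 to compound 3 (0.97 log units; beyond the scatter), which is modest, and both lie beyond the scatter.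

Compound 4 `COC(=O)C#CC(O/C=C/C(=O)OC)C1CC1` has not yet been measured. It differs from compound 3 by cyclopropyl in place of tert-butyl on a saturated chain carbon bound to an oxygen on an unsaturated carbon and a triple-bonded carbon, with cyclopropyl in place of tert-butyl on a saturated chain carbon bound to an oxygen on an unsaturated carbon and a triple-bonded carbon. Going by the values given here, no measured compound carries cyclopropyl, so the only guides are the steps to compound 3 from the two open chains. Read in reverse, a 9.4-fold higher number from compound 2 to compound 3 (0.97 log units; beyond the scatter) suggests that removing tert-butyl could bring the number down, though probably not the whole way. The expected step is a 3.8-fold lower number from compound 3 to compound 4 (0.57 log units; beyond the scatter), an estimate pointing to a lower number. Compound 4 is expected near 800 nM, with an estimated range from 280 nM to 2300 nM.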

Compound 4, concentration for 50% growth inhibition: 1800 nM
Compound 4: middle estimate off by 2.3-fold (0.35 log units), on the low side; measured number inside the range.
By their numbers in this assay, from the lowest: compounds 1 and 2 (each within the scatter of the next); then compounds 4 and 3 (each within the scatter of the next).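

In this assay, a 1.7-fold lower number from compound 3 to compound 4 (0.22 log units; within the scatter) means that cyclopropyl and tert-butyl cannot be told apart on this saturated chain carbon, so exchanging tert-butyl for the ring does not by itself restore the numbers of the open chains. The gap to those chains remains, with a 5.6-fold higher number from compound 2 to compound 4 (0.75 log units; beyond the scatter) and a 7.5-fold higher number from compound 1 to compound 4 (0.88 log units; beyond the scatter), so the four compounds fall into two sets at this position: butyl and propyl give the lower numbers, while tert-butyl and cyclopropyl give the higher ones, and no compound shown goes against this split. Nothing available here accounts for the split.

The compounds shown leave open where a branched chain such as isopropyl, a larger ring such as cyclohexyl or a longer chain such as hexyl would fall relative to these two sets. They also leave open whether an amine or a carboxylic acid carried on the butyl chain would keep a number close to that of compound 1 at 240 nM in this assay.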